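This account rests on a few compounds, and the source may have more. Where it says the series, first, only, none or still open, it means among the compounds named here.

Working notes on the series. In an ADME assay on the whole organism (Rattus norvegicus) for pharmacokinetics, read by HPLC, at a dose of 3 mg/kg by the oral route (on this read-out lower numbers stand for lower exposure and higher numbers for higher exposure at the dose given), compound 1 (`N#Cc1cc(C(=O)N2CS(=O)(=O)c3ccccc32)cc(Cl)c1O`) gives 3870 nM and compound 2 (`CC(C)c1cc(C(=O)N2CS(=O)(=O)c3ccccc32)cc(C#N)c1O`) gives 12500 nM while compound 3 (`CCc1cc(C(=O)N2CS(=O)(=O)c3ccccc32)cc(C#N)c1O`) gives 12400 nM as its maximal plasma concentration. Hydrogen in place of methyl on the chain gives a 1.0-fold lower number from compound 2 to compound 3 (0.00 log units; within the scatter) and so leaves compound 3 with no separation from its nearest neighbour. Ethyl in place of chloro gives a 3.2-fold higher number from compound 1 to compound 3 (0.51 log units; beyond the scatter) and isopropyl in place of chloro gives a 3.2-fold higher number from compound 1 to compound 2 (0.51 log units; beyond the scatter) as modest steps.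

The next change is ethynyl in place of ethyl on an aromatic carbon, which leads to compound 4 (`C#Cc1cc(C(=O)N2CS(=O)(=O)c3ccccc32)cc(C#N)c1O`). For the measured compounds named here, no measured step has ethynyl on either side, so the evidence is indirect. Going by the values given here, the only change at this place that moved the number beyond the scatter is the one from chloro to the two alkyl groups, and ethynyl is neither chloro nor alkyl. A position between compound 1 and compound 3 is therefore the working expectation, with a 3.2-fold higher number from compound 1 to compound 3 (0.51 log units; beyond the scatter) as a guide to the size of any fall. The expected step is a 1.6-fold lower number from compound 3 to compound 4 (0.19 log units; within the scatter) and its direction is uncertain. The estimated value for compound 4 is 8000 nM (expected range 3500 nM to 16000 nM).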

Compound 4, maximal plasma concentration: 4670 nM
Beside the measured number, compound 4's estimate is 1.7-fold (0.23 log units) above it; the range from low to high includes it.
By their numbers in this assay, from the lowest: compounds 1 and 4 (each within the scatter of the next); then compounds 3 and 2 (each within the scatter of the next).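

In this assay the number at this place, on an aromatic carbon ortho to a hydroxy group and meta to a cyano group, depends on more than the size of the substituent: with 2 heavy atoms on each side, ethynyl in place of ethyl gives a 2.7-fold lower number from compound 3 to compound 4 (0.42 log units; beyond the scatter) on a swap that adds no hydrogen-bond donor or acceptor, and ethynyl in place of isopropyl gives a 2.7-fold lower number from compound 2 to compound 4 (0.43 log units; beyond the scatter) in the same direction. Ethynyl in place of chloro gives a 1.2-fold higher number from compound 1 to compound 4 (0.08 log units; within the scatter) and so puts compound 4 level with compound 1, which leaves ethyl and isopropyl as the only two of the four groups shown here that reach the higher level. No measurement offered here accounts for this separation.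

Going by these compounds, whether a vinyl group, with a double bond in place of the triple bond, falls with the ethyl and isopropyl compounds or with compound 1 and compound 4 remains open, as does the outcome for a longer chain such as propyl or for methoxy at this place. On these data alone, it is also open whether the separation seen in this assay extends to other measures of exposure, such as the area under the curve.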